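Swapping Bromo for Trifluoromethyl on the Aryl Ring

The source may report more compounds than this note shows. Statements on the series, on what has been measured and on what is new or still open speak of the compounds shown alone.

Compound 1 `COc1ccc(-c2nc(CSc3cccc(Br)c3)nc3ccsc23)cn1` was examined in an ADME assay on cells (Homo sapiens) for cytotoxicity, read by resazurin assay, with a stated time of 5 days; a lower number here means that less compound is tolerated, a higher number that more compound is tolerated. In this assay compound 1 gives > 50000 nM, which is a limit of the assay rather than a number. Compound 2 `COc1ccc(-c2nc(C[S+]([O-])c3cccc(Cl)c3)nc3ccsc23)cn1` likewise reaches only a limit, > 50000 nM. Compound 3 `COc1ccc(-c2nc(CC(O)c3cccc(Cl)c3)nc3ccsc23)cn1` gives 31000 nM. The measured steps a step that the two limits leave unreadable from compound 1 to compound 2, an at least 1.6-fold lower number from compound 1 to compound 3 (0.20 log units; that floor lies within the scatter) and an at least 1.6-fold lower number from compound 2 to compound 3 (0.20 log units; that floor lies within the scatter) all exchange the group on the saturated chain carbon bound to an aromatic carbon, and two of the three values sit at the limit of > 50000 nM in this assay, at which 2 of the 3 values shown sit. Compound 4 `COc1ccc(-c2nc(CSc3cccc(C(F)(F)F)c3)nc3ccsc23)cn1` differs from compound 1 elsewhere, by trifluoromethyl in place of bromo on an aromatic carbon. Going by the values given here, no measured step touches that aromatic carbon, so no shift beyond the scatter is expected, and compound 4 is expected to give 50000 nM, in the range 25000 nM to 150000 nM, a step of a number no higher from compound 1 to compound 4 (the limit leaves the size open).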

Compound 4, half-maximal cytotoxic concentration: > 50000 nM
Compound 4 gave a limit, no number; the forecaster's own chance of this, stated with the estimate: 70%; the middle value sits exactly at the limit.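

No step can be read between compound 1 and compound 4, because both values are limits of the assay and not numbers: the limit of > 50000 nM in this assay, at which 3 of the 4 values shown sit.

The compounds shown leave open whether trifluoromethyl in place of bromo changes the tolerated concentration at all in this assay.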